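The source may report more compounds than this note shows. Statements on the series, on what has been measured and on what is new or still open speak of the compounds shown alone.

The measured compounds:
compound 1, `CC(C)c1c(C(=O)NCc2ccccc2)nn(-c2ccc(F)cc2)c1OC[C@@H](O)C[C@@H](O)CC(=O)O`, which in an assay on microsomes from liver for inhibition of 3-hydroxy-3-methylglutaryl-coenzyme A reductase (Rattus norvegicus) (a higher number here means a weaker inhibitor, a lower number a stronger inhibitor), gives 3.8 nM;
compound 2, `CC(C)c1c(C(=O)NCc2cccc(F)c2F)nn(-c2ccc(F)cc2)c1OC[C@@H](O)C[C@@H](O)CC(=O)O`, which in this assay gives 2 nM;
compound 3, `CC(C)c1c(C(=O)N2CCCC2c2ccccc2)nn(-c2ccc(F)cc2)c1OC[C@@H](O)C[C@@H](O)CC(=O)O`, which in this assay gives 14 nM.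

Compound 1 holds the second highest of the three numbers. Its nearest neighbour is compound 2, with a 1.9-fold lower number from compound 1 to compound 2 (0.28 log units; within the scatter), and its furthest is compound 3, with a 3.7-fold higher number from compound 1 to compound 3 (0.57 log units; beyond the scatter). Between the other two, the distance is a 7.0-fold higher number from compound 2 to compound 3 (0.85 log units; beyond the scatter).

Compound 4, `Cc1cccc(CNC(=O)c2nn(-c3ccc(F)cc3)c(OC[C@@H](O)C[C@@H](O)CC(=O)O)c2C(C)C)c1`, departs from compound 1 by a single change: methyl in place of hydrogen on an aromatic carbon. For the measured compounds named here, two measured steps bear on it. The step from compound 1 to compound 2 also altered the benzyl ring, by fluorine substitution, and it stayed within the scatter. The step from compound 1 to compound 3 exchanged the whole benzylamino group and moved the number by a modest amount; it is a far larger structural change than a single methyl and so is only a loose guide. On this basis a shift beyond the scatter is not expected in this assay for compound 4. The number for compound 4 is estimated at 3.5 nM, with a range from 1.5 nM to 9 nM, which corresponds to an expected step of a 1.1-fold lower number from compound 1 to compound 4 (0.04 log units; within the scatter).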

Compound 4, half-maximal inhibitory concentration: 4.9 nM
Compound 4: middle estimate off by 1.4-fold (0.15 log units), on the low side; the measured number falls inside the stated range.
By their numbers in this assay, from the lowest: compounds 2, 1 and 4 (each within the scatter of the next, the first and the last beyond it); then compound 3.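

In this assay, for the compounds shown here, a methyl group on this aromatic carbon, meta to a large group, is the first carbon substituent on the benzyl ring, and it leaves the number within the scatter of the unsubstituted ring, with a 1.3-fold higher number from compound 1 to compound 4 (0.11 log units; within the scatter). The result also shows that substitution on this ring can separate compounds even when neither differs measurably from compound 1: a 2.5-fold higher number from compound 2 to compound 4 (0.39 log units; beyond the scatter), so 3-methylbenzyl and 2,3-difluorobenzyl are distinguishable here, although each lies within the scatter of plain benzyl. The methyl group also keeps the (3-methylbenzyl)amino compound apart from the 2-phenylpyrrolidin-1-yl amide, with a 2.9-fold lower number from compound 3 to compound 4 (0.46 log units; beyond the scatter), but nothing given here explains any of these differences.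

The compounds shown leave open whether a larger group on the same aromatic carbon, such as methoxy or trifluoromethyl, would also stay within the scatter of compound 1 in this assay. They also leave open how a single fluorine at this place would compare with the methyl group of compound 4, and so which of the two fluorines in compound 2 accounts for its separation from compound 4.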